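Cyclopropyl for cyclopentyl in the cytotoxicity readout

The compounds below may be only part of what the source reports. "The series", "measured", "known", "first", "only" and "open" are said of these compounds alone.

compound 1 `OC[C@H]1O[C@@H](n2cnc3c(NC4CCCC4)nc(NC4CCCC4)nc32)[C@H](O)[C@@H]1O` gives > 500000 nM
compound 2 `OC[C@H]1O[C@@H](n2cnc3c(NCc4cccc5ccccc45)nc(NCCC(c4ccccc4)c4ccccc4)nc32)[C@H](O)[C@@H]1O` gives "not determined" (no result reported)
compound 3 `OC[C@H]1O[C@@H](n2cnc3c(N4CCCCC4)nc(N4CCCCC4)nc32)[C@H](O)[C@@H]1O` gives "not determined" (no result reported)

In an ADME assay on HEK-293T cells (Homo sapiens) for cytotoxicity, read by resazurin assay, with a stated time of 16 h (a lower number here means a stronger inhibitor, a higher number a weaker inhibitor), compound 1 gives > 500000 nM and this is a limit of the assay, not a number. Going by the values given here, compound 2 and compound 3 have no result, so the set holds no measured step. For compound 1 the sole anchor is the limit of > 500000 nM in this assay, at which 1 of the 3 values shown sits, and no other reading stands beside it.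

The next compound to be tested is compound 4 `OC[C@H]1O[C@@H](n2cnc3c(NC4CC4)nc(NC4CCCC4)nc32)[C@H](O)[C@@H]1O` which differs from compound 1 at one place cyclopropyl in place of cyclopentyl on a nitrogen on an aromatic ring with cyclopropyl in place of cyclopentyl on a nitrogen on an aromatic ring. Cut one bond further out, the same difference reads cyclopentylamino to cyclopropylamino, while the rest of the core of compound 1 stays as it is.

In this assay no step beyond the scatter is expected, and the most likely report for compound 4 is again a limit. This expectation rests on compound 1 with > 500000 nM as its only support, so it remains weak. The expected step is a number no higher from compound 1 to compound 4 (the limit leaves the size open) as a working estimate. For compound 4 the estimated value is 500000 nM with an expected range from 200000 nM to 1000000 nM.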

Compound 4, half-maximal inhibitory concentration: > 500000 nM
Compound 4: no number, only a limit; the forecaster's own chance of this, stated with the estimate: 80%; the middle value lies on the limit itself.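

In this assay compound 4 gives > 500000 nM as a limit of the assay and not a number. Compound 1 also stands at a limit, so no step can be read between compound 1 and compound 4: the limit of > 500000 nM in this assay, at which 2 of the 4 values shown sit. The compounds shown leave open whether any change on the shared core gives a measurable value in this assay at all.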